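Cytotoxicity limits across a fused sulfonylurea series

A few compounds are considered here, and "the series" means these few. Any claim that something is new, unique, unknown or untested is made for them only; others in the source may bear on it.

Compound 1 `C=CCN1C(=O)N(Cc2ccccc2)S(=O)(=O)n2cccc21` was examined in an ADME assay on MT4 cells (Homo sapiens) for cytotoxicity, read by MTT assay, with a stated time of 5 days (a lower number here means that less compound is tolerated, a higher number that more compound is tolerated), where it reached only a limit, giving > 802000 nM. That reading is the limit of > 802000 nM in this assay, at which 1 of the 3 values shown sits, and it is the highest of the three limits recorded. Compound 2 `O=C1N(Cc2ccccc2Cl)c2cscc2S(=O)(=O)N1Cc1ccccc1` likewise stopped at a limit in this assay, at > 119000 nM. Compound 3 `O=C1N(Cc2ccccc2Br)c2cccn2S(=O)(=O)N1Cc1cccc(F)c1` too gave only a limit in this assay, > 269000 nM. No pair among these three differs in a single place, so no step between measured compounds can be drawn; what the three readings share is that none resolved into a number, each ending at the limit of this assay.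

Compound 4 `O=C1N(Cc2ccc(F)cc2)c2cccn2S(=O)(=O)N1Cc1ccccc1` is related to compound 1 by one change: 4-fluorophenyl in place of vinyl on a saturated chain carbon bound to an amide-type nitrogen in a ring, that is, allyl to 4-fluorobenzyl. Since nothing here has produced a measurable half-maximal cytotoxic concentration, the step from compound 1 to compound 4 is expected to be none beyond the scatter, with an at least 2.6-fold lower number from compound 1 to compound 4 (0.42 log units; beyond the scatter) likely reflecting only the position of the limit rather than a real shift. Compound 4 is therefore estimated at 300000 nM in this assay, within a range of 100000 nM to 1000000 nM, most probably reported once more as a limit.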

Compound 4, half-maximal cytotoxic concentration: 150000 nM
Estimate against measurement, compound 4: 2.0-fold (0.30 log units) above; the measured number falls inside the stated range.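

Compound 4 alone among the compounds shown gives a resolved number in this assay, so the series no longer rests on limits only. Placing 4-fluorophenyl in place of vinyl on a saturated chain carbon bound to an amide-type nitrogen in a ring gives an at least 5.3-fold lower number from compound 1 to compound 4 (0.72 log units; beyond the scatter), which shows that a change at this position can register in the read-out, with less compound tolerated. Compound 1 stands at a limit, so the step gives only a lower bound on the size of the change: the limit of > 802000 nM in this assay, at which 1 of the 4 values shown sits.

The other pairs among these compounds differ in more than one place, so their steps cannot be read, and compound 4 cannot be set against compound 2 or compound 3 to say anything about the fluorine or the core. From the compounds shown here alone, whether the step from allyl to 4-fluorobenzyl follows the aromatic ring or the fluorine stays open, and a plain benzyl group, a longer chain or an amine in this place would be needed to tell these apart.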